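The compounds below may be only part of what the source reports. "The series", "measured", "known", "first", "only" and "open" are said of these compounds alone.

Compound 1 `Cc1oc(C(=O)O)cc1COc1ccc(-c2ccc(Cl)cc2)cc1`: 1000 nM
Compound 2 `Cc1oc(C(=O)O)cc1COc1ccc(-c2ccc(C#N)cc2)cc1`: 1500 nM

In an assay on cells for displacement of a labelled ligand from prostaglandin E2 receptor EP4 subtype (Homo sapiens), read by scintillation counting (on this read-out lower numbers stand for stronger inhibition and higher numbers for weaker inhibition), compound 2 gives 1500 nM, the higher of the two numbers, and compound 1 gives 1000 nM; the two lie within the scatter. Compound 3 `Cc1oc(C(=O)O)cc1COc1ccc(-c2ccc(OC(F)(F)F)cc2)cc1` carries trifluoromethoxy in place of cyano on an aromatic carbon. Among the compounds with values here, the only measured step in this assay that bears on a change at this aromatic carbon is a 1.5-fold higher number from compound 1 to compound 2 (0.18 log units; within the scatter), which stayed within the scatter. The step for compound 3 is therefore expected to be a 1.7-fold lower number from compound 2 to compound 3 (0.22 log units; within the scatter), with no shift beyond the scatter clearly foreseen. Compound 3 is estimated at 900 nM, in the range 300 nM to 2700 nM.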

Compound 3, inhibition constant: 2400 nM
Beside the measured number, compound 3's estimate is 2.7-fold (0.43 log units) below it; low and high end bracket the measured number.
By their numbers in this assay, from the lowest: compounds 1, 2 and 3 (each within the scatter of the next, the first and the last beyond it).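

In this assay, within the data shown here, trifluoromethoxy on this aromatic carbon, para to a large group, gives the first step at this position that lies beyond the scatter, though the shift is modest, with a 2.4-fold higher number from compound 1 to compound 3 (0.38 log units; beyond the scatter) in place of chloro. In place of cyano, the same group stays within the scatter, with a 1.6-fold higher number from compound 2 to compound 3 (0.20 log units; within the scatter) despite its 5 heavy atoms against 2. Nothing available explains either step. As far as these compounds go, whether an amine or a carboxylic acid on this carbon would bring a number lower than that of compound 1 remains open.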